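Swapping a Hydroxyethyl Group for an Aryl Group: Expected Cytotoxicity

The source may hold more compounds than are shown below. What is called first, only, known or untested is meant among the compounds shown, and "the series" means these compounds.

Of the compounds shown here, two sharing one core have been measured in an ADME assay on L6 cells (Rattus norvegicus) for cytotoxicity, read by resazurin assay, with a stated time of 70 h; on this read-out lower numbers stand for stronger inhibition and higher numbers for weaker inhibition. Compound 1, `COc1cc(NC(C)CCCNC(=O)Nc2ccc(O)cc2)c2ncccc2c1`, gives 14.8 ug/mL in this assay. Compound 2, `COc1cc(NC(C)CCCNC(=O)NNC(=O)N(CCO)CCO)c2ncccc2c1`, gives 79.9 ug/mL in this assay. For the measured compounds named here, of the two numbers, compound 2 stands highest, and its nearest neighbour is compound 1: the single change between them, (bis(2-hydroxyethyl)carbamoyl)amino in place of 4-hydroxyphenyl on an amide-type nitrogen, brought a 5.4-fold higher number from compound 1 to compound 2 (0.73 log units; beyond the scatter), so the hydroxyethyl-bearing compound is the weaker inhibitor of the two.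

Compound 3, `COc1cc(NC(C)CCCNC(=O)NNC(=O)Nc2ccc(Cl)c(C(F)(F)F)c2)c2ncccc2c1`, is not yet measured in this assay. It differs from compound 2 in one place: (4-chloro-3-(trifluoromethyl)phenyl)amino in place of bis(2-hydroxyethyl)amino on a carbonyl carbon. Going by the values given here, the only step that bears on this is the one from compound 1 to compound 2, in which a phenyl-type group gave way to a hydroxyethyl-bearing group and the number rose. Compound 3 moves back toward an aryl group, so a drop in the number is expected for compound 3, roughly a 5.3-fold lower number from compound 2 to compound 3 (0.73 log units; beyond the scatter), because compound 1 with its aryl group gave 14.8 ug/mL. Compound 3 is therefore expected to give about 15 ug/mL in this assay, within a range from 5 ug/mL to 50 ug/mL.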

Compound 3, half-maximal inhibitory concentration: 30 ug/mL
Compound 3: the middle estimate sits 2.0-fold (0.30 log units) below what was measured; measured number inside the range.
By their numbers in this assay, from the lowest: compound 1; then compound 3; then compound 2.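

With the carbonyl and its amide-type nitrogen held in place, the new step isolates the group on the carbonyl carbon, whereas the earlier step from compound 1 to compound 2 replaced a larger piece of the molecule. In this assay, putting (4-chloro-3-(trifluoromethyl)phenyl)amino in place of bis(2-hydroxyethyl)amino gives a 2.7-fold lower number from compound 2 to compound 3 (0.43 log units; beyond the scatter), so this end group alone moves the read-out by more than the usual scatter, toward stronger inhibition. The data offer no measurement that explains this shift.

The step changes several things at once, since the aromatic ring, the chlorine and the trifluoromethyl all enter together while the hydroxyethyl arms leave, so the compounds shown cannot say which of these changes matters. A plain phenylamino group, a phenylamino group carrying only chlorine or only trifluoromethyl, and a morpholine ring on the same carbonyl carbon would help to separate these contributions and show whether the aromatic ring itself or its substituents account for the lower number.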